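A few compounds are considered here, and "the series" means these few. Any claim that something is new, unique, unknown or untested is made for them only; others in the source may bear on it.

Series notes. In an assay on isolated protein with Bile acid receptor (Homo sapiens) as the target (on this read-out higher numbers stand for an effect only at larger amounts of compound and lower numbers for an effect already at smaller amounts), compound 1 `COC(=O)/C=C/c1cccc(N(Cc2ccc(/C=C/c3ccc(F)cc3)cc2)C(=O)NC(C)C)c1` gives 348 nM. Compound 2 `COC(=O)/C=C/c1cccc(N(Cc2ccc(/C=C/c3ccccn3)cc2)C(=O)C2CCCCC2)c1` gives 309 nM in this assay, and compound 3 `COC(=O)/C=C/c1cccc(N(Cc2ccc(/C=C/c3ccccn3)cc2)C(=O)C(C)C)c1` gives 310 nM. Among the compounds with values here, the only measured step, a 1.0-fold higher number from compound 2 to compound 3 (0.00 log units; within the scatter), concerns the group on the carbonyl carbon. In this assay compound 3 stands second highest of the three numbers, with compound 2 nearest and compound 1 furthest, both gaps within the scatter. Compound 4 `COC(=O)/C=C/c1cccc(N(Cc2ccc(-c3cccc(C)c3)cc2)C(=O)C(C)C)c1` differs from compound 3 by 3-methylphenyl in place of 2-(pyridin-2-yl)ethenyl on an aromatic carbon. Within the data shown here, no measured step touches this aromatic position, and the single step in hand sits elsewhere, so the expected step of a 1.3-fold higher number from compound 3 to compound 4 (0.11 log units; within the scatter) in this assay is set near zero with a wide range. Compound 4 is estimated at 400 nM in this assay, range 120 nM to 1300 nM.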

Compound 4, half-maximal effective concentration: 163 nM
Beside the measured number, compound 4's estimate is 2.5-fold (0.39 log units) above it; measured number inside the range.
By their numbers in this assay, from the lowest: compounds 4, 2, 3 and 1 (each within the scatter of the next, the first and the last beyond it).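

Within the data shown here, replacing 2-(pyridin-2-yl)ethenyl with 3-methylphenyl on the aromatic carbon para to a large group gives the first reading at this position in this assay (a 1.9-fold lower number from compound 3 to compound 4 (0.28 log units; within the scatter)). A group without a ring nitrogen or a double bond outside aromatic rings therefore reads within the scatter of one carrying both. No evidence on the cause of this step is in hand.

As far as these compounds go, it remains open whether an amine or a carboxylic acid in place of the methyl of 3-methylphenyl would keep the number in this range. The same holds for 3-methylphenyl paired with the cyclohexyl group of compound 2.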